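The source may hold more compounds than are shown below. What is called first, only, known or untested is meant among the compounds shown, and "the series" means these compounds.

Of the compounds shown here, two built on one shared core have so far been measured in a functional assay on NCI-H226 cells (Homo sapiens) for inhibition, read by MTT assay, with a stated time of 48 h, tested at 10 uM; on this read-out higher numbers stand for more inhibition at the one concentration tested (going by the name of the read-out) and lower numbers for less inhibition. Compound 1 `COc1cc(NC(=O)Nc2cc(Nc3cccc(C(C)(C)C)c3)ncn2)cc(OC)c1` gives 40% in this assay. Compound 2 `COc1cc(NC(=O)Nc2cc(Nc3cc(F)ccc3OC)ncn2)cc(OC)c1` gives 37.7% in this assay. Among the compounds with values here, the only measured step, a number 2.3 percentage points lower from compound 1 to compound 2 (within the scatter), exchanges one whole aryl group on a nitrogen for another, and its size does not leave the scatter. Within the data shown here, compound 2 thus holds the lower of the two numbers, but its only neighbour, compound 1, sits within the scatter of it, so the two cannot be told apart.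

Compound 3 `COc1cc(NC(=O)Nc2cc(Nc3cc(C(F)(F)F)ccc3OC)ncn2)cc(OC)c1` is the next member. It differs from compound 2 by trifluoromethyl in place of fluoro on an aromatic carbon. Among the measured compounds shown here, no measured step bears directly on this exchange: the one step known changes the whole aryl group, not a single substituent on it, and even that step stays within the scatter. Nothing here points to a step in this assay beyond the scatter in either direction. Compound 3 is therefore expected to give about 38%, with a range from 20% to 56%. The step this estimate means, a number 0.3 percentage points higher from compound 2 to compound 3 (within the scatter), is expected to lie within the scatter.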

Compound 3, a percentage reported as inhibition, at one concentration (the size of the read-out at that concentration, not a potency): 60%
Beside the measured number, compound 3's estimate is 22 percentage points below it; measured number outside the range, above it.
By their numbers in this assay, from the lowest: compounds 2 and 1 (each within the scatter of the next); then compound 3.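

In this assay the aromatic carbon para to a methoxy group proves able to shift the number well past the scatter: the exchange of trifluoromethyl for fluoro there gives a number 22.3 percentage points higher from compound 2 to compound 3 (beyond the scatter) and is the only step shown so far to leave the scatter. The earlier step, a number 2.3 percentage points lower from compound 1 to compound 2 (within the scatter) and within the scatter, swapped one whole aryl group on a nitrogen for another, so it gave no sign that a single substituent on that aryl group could matter this much; the new result shows that, with the rest of the molecule unchanged, one substituent can do so. Nothing available here bears on why the number rises with this exchange. The compounds shown hold only fluoro and trifluoromethyl at this carbon, so they leave open how a chloro, a methyl or a nitrile would read there, and whether the number simply climbs with the four heavy atoms of trifluoromethyl or depends on that group itself. They also leave open whether the same exchange would give a similar step if the methoxy group were replaced by an ethoxy or a hydroxyl group, and whether a reading at one concentration would carry over to a measure of potency.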